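A 4-hydroxyphenyl group replaces 2,4-dichlorophenyl

A few compounds are considered here, and "the series" means these few. Any claim that something is new, unique, unknown or untested is made for them only; others in the source may bear on it.

Measured values from a functional assay (a lower number here means a stronger inhibitor, a higher number a weaker inhibitor), follow
Compound 1 (`CC(C)=CCOc1ccc2c(c1)OC(c1ccccc1)CC2=O`) gives 6070 nM
Compound 2 (`CC(C)=CCOc1ccc2c(c1)OC(c1ccc(Cl)cc1Cl)CC2=O`) gives 5260 nM

Compound 2 stands level with compound 1, since their two numbers lie within the scatter of each other. Compound 3 (`CC(C)=CCOc1ccc2c(c1)OC(c1ccc(O)cc1)CC2=O`) differs from compound 2 at one place on the shared core (4-hydroxyphenyl in place of 2,4-dichlorophenyl on a saturated ring carbon), with 4-hydroxyphenyl in place of 2,4-dichlorophenyl on a saturated ring carbon, next to the ring oxygen. Among the measured compounds shown here, only one measured step bears on this change, and it concerns the same place (a 1.2-fold lower number from compound 1 to compound 2 (0.06 log units; within the scatter)). For the measured compounds named here, that step stays within the scatter, but no measured compound carries the 4-hydroxyphenyl group, so the evidence is thin. No step beyond the scatter is therefore expected in this assay, in either direction, and the range stays wide. The estimated step is small (a 1.1-fold lower number from compound 2 to compound 3 (0.02 log units; within the scatter)). For compound 3 the estimated value is 5000 nM (expected range 1500 nM to 16000 nM).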

Compound 3, half-maximal inhibitory concentration: 6670 nM
Compound 3: the middle estimate sits 1.3-fold (0.13 log units) below what was measured, and the stated range covers the measured number.
By their numbers in this assay, from the lowest: compounds 2, 1 and 3 (each within the scatter of the next).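

Until now, the saturated ring carbon next to the ring oxygen had carried only phenyl and 2,4-dichlorophenyl, neither with a hydrogen-bond donor or acceptor. The 4-hydroxyphenyl group brings one of each, yet in this assay the swap for 2,4-dichlorophenyl gives a 1.3-fold higher number from compound 2 to compound 3 (0.10 log units; within the scatter), and adding hydroxy to the plain phenyl ring gives a 1.1-fold higher number from compound 1 to compound 3 (0.04 log units; within the scatter), so compound 1, compound 2 and compound 3 cannot be told apart. No other measurement is available to explain this flat result.

Still open, on these data alone, is whether a group of a different kind at this place, such as an amine, a carboxylic acid or a longer alkyl chain, would separate from these three. As far as these compounds go, the rest of the shared core is identical across all three compounds, so its contribution remains unknown.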